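The source may report more compounds than this note shows. Statements on the series, on what has been measured and on what is new or still open speak of the compounds shown alone.

Measured so far:
compound 1, `COC(=O)COc1cccc(/C=C/c2ccc3ccccc3n2)c1` — in a functional assay on lung (Cavia porcellus) for binding affinity to cysteinyl leukotriene receptor (Homo sapiens) (a higher number here means a weaker inhibitor, a lower number a stronger inhibitor), compound 1 gives 1000 nM
compound 2, `O=C(O)CCCOc1cccc(/C=C/c2ccc3ccc(Cl)cc3n2)c1` — in this assay compound 2 gives 39 nM

Compound 2 stands lowest of the two numbers; its nearest neighbour is compound 1, whose value lies higher by a gap well beyond the scatter. Going by the values given here, compound 1 and compound 2 differ in more than one place, so their two values show only that the pair sits far apart, not what any single change does. Compound 3, `O=C(O)CCCOc1cccc(/C=C/c2ccc3ccccc3n2)c1`, is not yet measured. It differs from compound 2 in one place: hydrogen in place of chloro on an aromatic carbon. Among the compounds with values here, no measured pair with this same change exists to lean on. Taking this chloro away is expected to cost some potency, a step upward in this assay of a 2.6-fold higher number from compound 2 to compound 3 (0.41 log units; beyond the scatter), though a result within the scatter would not be a surprise. Compound 3 is therefore expected to give about 100 nM, in a range from 30 nM to 400 nM.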

Compound 3, half-maximal inhibitory concentration: 480 nM
For compound 3 the middle estimate is 4.8-fold (0.68 log units) below the measured one; measured number above the stated range.
By their numbers in this assay, from the lowest: compound 2; then compound 3; then compound 1.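

Replacing the chloro with hydrogen on this aromatic carbon of the fused system gives a 12-fold higher number from compound 2 to compound 3 (1.09 log units; beyond the scatter) in this assay, so this one atom weighs far more than compounds 1 and 2 alone could reveal. The change in the side chain, 2-carboxyethyl in place of methoxycarbonyl, gives a much smaller step (a 2.1-fold lower number from compound 1 to compound 3 (0.32 log units; beyond the scatter)), so along the route through compound 3, most of the wide gap between compound 1 and compound 2 goes with the chloro. Nothing available here explains why this chloro counts for so much.

On these data alone, it remains open whether fluoro, bromo or methoxy on the same carbon would keep the potency of compound 2. Also open, as far as these compounds go, is how a carboxylic acid on the shorter chain of compound 1 would compare with its methyl ester.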